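The source may report more compounds than this note shows. Statements on the series, on what has been measured and on what is new or still open speak of the compounds shown alone.

Compound 1 `Cc1ccc2[nH]c(=O)c(CN(Cc3ccccc3)Cc3ccc(C(C)(C)C)cc3)cc2c1`: > 5000 nM
Compound 2 `COc1ccc(CN(Cc2ccc(C(C)(C)C)cc2)Cc2cc3cc(C)ccc3[nH]c2=O)cc1`: > 10000 nM

In a toxicity assay on MDCK cells (Canis lupus familiaris) for cytotoxicity, read by crystal violet staining, with a stated time of 48 h (on this read-out higher numbers stand for lower toxicity in this test and lower numbers for higher toxicity in this test), compound 1 gives only a limit, > 5000 nM. Compound 2 also gives only a limit in this assay, > 10000 nM. Compound 2 thus stands at the limit of > 10000 nM in this assay, at which 1 of the 2 values shown sits. Among the compounds with values here, the one measured step, a step that the two limits leave unreadable from compound 1 to compound 2, starts from the limit of > 5000 nM in this assay, at which 1 of the 2 values shown sits, and therefore cannot be read. Compound 3 `Cc1ccc2[nH]c(=O)c(CN(Cc3ccc(OC(C)C)cc3)Cc3ccc(C(C)(C)C)cc3)cc2c1` differs from compound 2 by isopropyl in place of methyl on an oxygen on an aromatic ring. Within the data shown here, no measured step bears on this change, and neither value shown leaves its limit. Compound 3 is accordingly expected to stay at the limit of this assay, with the step that the limit leaves unreadable from compound 2 to compound 3 expected to show nothing readable. Its value for compound 3 is estimated at 15000 nM, ranging from 6000 nM to 50000 nM.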

Compound 3, half-maximal cytotoxic concentration: > 5000 nM
Compound 3: no number, only a limit; the forecaster's own chance of this, stated with the estimate: 85%; the middle value is on the limit's open side.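

In this assay, within the data shown here, compound 1, compound 2 and compound 3 all give only limits, so no step among them can be read. The compounds shown leave open where each true value lies and whether either methoxy or isopropoxy changes it.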